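Series notes: from compound 3 to compound 4

The compounds below may be only part of what the source reports. "The series", "measured", "known", "first", "only" and "open" are said of these compounds alone.

Of the compounds shown here, three carry numbers so far. Compound 1 `CCC(/C=C1\OC(=O)NC1=O)(CC)c1ccc(-c2ccc3cccc(C(F)(F)F)c3c2)[nH]c1=O` gives 230 nM in an assay on membranes from Chem-1 cells for displacement of a labelled ligand from prostaglandin E2 receptor EP3 subtype (Homo sapiens), read by scintillation counting, with a stated time of 2 h; a lower number here means a stronger inhibitor, a higher number a weaker inhibitor. Compound 2 `CC(C)[C@H](C[C@H]1OC(=O)NC1=O)c1ccc(-c2ccc3cccc(F)c3c2)[nH]c1=O` gives 6 nM in this assay, and compound 3 `CC(C)[C@@H](c1ccc(-c2ccc3cccc(F)c3c2)[nH]c1=O)[C@H]1OC(=O)NC1=O` gives 27 nM. Compound 3 thus stands second highest of the three, with compound 2 as its nearest neighbour and compound 1 the furthest away. Going by the values given here, the only step that bears directly on the matter is a 4.5-fold higher number from compound 2 to compound 3 (0.65 log units; beyond the scatter).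

Compound 4 `CC(C)[C@H](C[C@@H]1OC(=O)NC1=O)c1ccc(-c2ccc3cccc(F)c3c2)[nH]c1=O` has not yet been measured. It differs from compound 3 as follows: (2,4-dioxo-1,3-oxazolidin-5-yl)methyl in place of 2,4-dioxo-1,3-oxazolidin-5-yl on a saturated chain carbon bound to an aromatic carbon and a saturated chain carbon. In kind this reverses the step from compound 2 to compound 3, although the entering group has its own defined stereocentre and compound 4 is not compound 2, so the size of the reversal is uncertain. A step of roughly that size toward a lower number is therefore expected in this assay, with a wide range. Compound 4 is estimated at 12 nM, between 4 nM and 60 nM. The expected step is a 2.3-fold lower number from compound 3 to compound 4 (0.35 log units; beyond the scatter).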

Compound 4, inhibition constant in the prostaglandin E2 receptor EP3 subtype assay: 8 nM
Compound 4: middle estimate off by 1.5-fold (0.18 log units), on the high side; measured number inside the range.
By their numbers in the prostaglandin E2 receptor EP3 subtype assay, from the lowest: compounds 2 and 4 (each within the scatter of the next); then compound 3; then compound 1.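

In the prostaglandin E2 receptor EP3 subtype assay, at this saturated chain carbon, (2,4-dioxo-1,3-oxazolidin-5-yl)methyl again gives a lower number than 2,4-dioxo-1,3-oxazolidin-5-yl, now with the other drawn configuration at the saturated ring carbon: a 3.4-fold lower number from compound 3 to compound 4 (0.53 log units; beyond the scatter). In the prostaglandin E2 receptor EP3 subtype assay that stereocentre, drawn R in compound 2 and S in compound 4, does not separate the two compounds, a 1.3-fold higher number from compound 2 to compound 4 (0.12 log units; within the scatter), and the comparison isolates this stereocentre: the fact that compounds 2 and 4 differ only in the configuration as drawn In a physicochemical assay for solubility, measured as kinetic solubility, at pH 2 (on this read-out higher numbers stand for higher solubility and lower numbers for lower solubility), compound 3 gives 5400 nM and compound 4 gives 25100 nM. The lower number in the prostaglandin E2 receptor EP3 subtype assay does not come with lower solubility in the physicochemical assay: the measured solubility of compound 3, 5400 nM, and of compound 4, 25100 nM, a 4.6-fold higher number (0.67 log units; beyond the scatter)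

Still open, as far as these compounds go, is whether a longer chain carrying the 2,4-dioxo-1,3-oxazolidin-5-yl ring, or a carboxylic acid in place of that ring, would keep the number in the prostaglandin E2 receptor EP3 subtype assay as low. The link to solubility rests on this single pair, so no trend can be drawn from it.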